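The source may hold more compounds than are shown below. What is called first, only, known or untested is meant among the compounds shown, and "the series" means these compounds.

In a physicochemical assay for solubility, read by chemiluminescence, measured as kinetic solubility (on this read-out lower numbers stand for lower solubility and higher numbers for higher solubility), compound 1 `CC(=O)NCc1cccc(Cn2nc(NS(=O)(=O)c3ccc(Cl)s3)c3ccccc32)c1` gives >= 117 ug/mL, which is a limit of the assay rather than a number. In this assay compound 2 `CC(=O)NCc1cccc(Cn2nc(NS(=O)(=O)c3ccc(Cl)s3)c3c(Cl)cccc32)c1` gives >= 226 ug/mL, again a limit. The step that the two limits leave unreadable from compound 1 to compound 2 therefore cannot be sized, and compound 2 stands only at a limit. Of the two values shown, one sits at the limit of >= 117 ug/mL in this assay, at which 1 of the 2 values shown sits. The other sits at the limit of >= 226 ug/mL in this assay, at which 1 of the 2 values shown sits.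

Compound 3 `CC(=O)NCc1cccc(Cn2nc(NS(=O)(=O)c3ccc(Cl)s3)c3c(C#N)cccc32)c1` differs from compound 2 by cyano in place of chloro on an aromatic carbon. For the measured compounds named here, the only measured step, between compound 1 and compound 2, concerns a different change and its size is not readable, so no measured step bears on this one, and nothing beyond the usual scatter is expected in this assay. Compound 3 is estimated to give 200 ug/mL, within a range from 60 ug/mL to 450 ug/mL. The estimated step is an at least 1.1-fold lower number from compound 2 to compound 3 (0.05 log units; that floor lies within the scatter), and the result may again be reported only as a limit.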

Compound 3, solubility: >= 155 ug/mL
Compound 3: a limit, no number (the forecaster's own chance of this, stated with the estimate: 50%); the middle value does not contradict the limit.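

In this assay compound 3 gives >= 155 ug/mL, which is a limit and not a number. Its steps from compound 1 and compound 2 therefore cannot be read. The compounds shown leave open whether hydrogen, chloro and cyano on this aromatic carbon differ in solubility at all.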